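Swapping the chlorophenyl for a dimethylphenyl: cytotoxicity expected

The compounds below may be only part of what the source reports. "The series", "measured", "known", "first", "only" and "open" are said of these compounds alone.

Among the measured compounds shown here, compound 2 `Cc1cc(S(N)(=O)=O)ccc1NC(=O)COc1ccc2cc(Br)ccc2c1C(=O)c1cccc(Cl)c1` gives 6800 nM in an ADME assay on C8166 cells (Homo sapiens) for cytotoxicity, read by colorimetric assay and MTT assay (a lower number here means that less compound is tolerated, a higher number that more compound is tolerated), the lower of the two numbers known so far, and compound 1 `Cc1cc(S(N)(=O)=O)ccc1NC(=O)COc1ccc2cc(Br)ccc2c1C(=O)c1ccccc1` gives 29200 nM. For the measured compounds named here, the single step between them, a 4.3-fold lower number from compound 1 to compound 2 (0.63 log units; beyond the scatter), is the only measured change that bears on what comes next. Compound 3 `Cc1cc(C)cc(C(=O)c2c(OCC(=O)Nc3ccc(S(N)(=O)=O)cc3C)ccc3cc(Br)ccc23)c1` differs from compound 2 by 3,5-dimethylphenyl in place of 3-chlorophenyl on a carbonyl carbon. Going by the values given here, with one modest step as the only guide, compound 3 is expected to stay close to compound 2, with a step of a 1.2-fold higher number from compound 2 to compound 3 (0.07 log units; within the scatter) that lies within the scatter. The estimate for compound 3 in this assay is 8000 nM, with a range from 3000 nM to 25000 nM.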

Compound 3, half-maximal cytotoxic concentration: 24500 nM
Compound 3: middle estimate off by 3.1-fold (0.49 log units), on the low side, within the range that was stated.
By their numbers in this assay, from the lowest: compound 2; then compounds 3 and 1 (each within the scatter of the next).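

The change on this carbonyl carbon gives a 3.6-fold higher number from compound 2 to compound 3 (0.56 log units; beyond the scatter) in this assay and so shows that the low number of compound 2 does not extend to every substituted phenyl. Adding the two methyl groups to the plain phenyl gives a 1.2-fold lower number from compound 1 to compound 3 (0.08 log units; within the scatter) and leaves the two groups indistinguishable here, so only 3-chlorophenyl stands apart so far. Nothing available explains why 3-chlorophenyl differs from the other two groups.

As far as these compounds go, it remains open whether an amine or a carboxylic acid on this phenyl ring would match compound 2 or fall with compound 1 and compound 3.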